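Aryl tail variation on the shared core

The source may report more compounds than this note shows. Statements on the series, on what has been measured and on what is new or still open speak of the compounds shown alone.

Measured so far:
compound 1, `O=c1[nH]/c(=N\OCCCc2cccc(I)c2)ccn1[C@@H]1O[C@H](COP(=O)(O)OP(=O)(O)OP(=O)(O)O)[C@@H](O)[C@H]1O`: 325 nM
compound 2, `COc1ccc(CCCO/N=c2/ccn([C@@H]3O[C@H](COP(=O)(O)OP(=O)(O)OP(=O)(O)O)[C@@H](O)[C@H]3O)c(=O)[nH]2)cc1`: 47 nM

Going by the values given here, in a functional assay on 1321-N1 cells for agonist activity at P2Y purinoceptor 2 (Homo sapiens), read by scintillation counting and inositol phosphate accumulation (on this read-out lower numbers stand for an effect already at smaller amounts and higher numbers for an effect only at larger amounts of compound), compound 2 holds the lowest of the two numbers, the only other being compound 1. Among the compounds with values here, the single measured step, a 6.9-fold lower number from compound 1 to compound 2 (0.84 log units; beyond the scatter), is at the same place as the change now considered. Compound 3, `O=c1[nH]/c(=N\OCCCc2ccc3ccccc3c2)ccn1[C@@H]1O[C@H](COP(=O)(O)OP(=O)(O)OP(=O)(O)O)[C@@H](O)[C@H]1O`, carries naphthalen-2-yl in place of 4-methoxyphenyl on a saturated chain carbon, three bonds along the chain from an oxygen on an unsaturated carbon. Within the data shown here, no measured step exchanges one aromatic ring for two fused rings, so that step bears on it only indirectly. A modest move back toward the number of compound 1 is expected, a 2.3-fold higher number from compound 2 to compound 3 (0.37 log units; beyond the scatter). Compound 3 is therefore estimated at 110 nM, between 35 nM and 350 nM.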

Compound 3, half-maximal effective concentration: 139 nM
For compound 3 the middle estimate is 1.3-fold (0.10 log units) below the measured one; the range from low to high includes it.
By their numbers in this assay, from the lowest: compound 2; then compound 3; then compound 1.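

In this assay the place on a saturated chain carbon, three bonds along the chain from an oxygen on an unsaturated carbon, also carries naphthalen-2-yl with a measurable effect. Replacing a single ring with two fused rings gives a 3.0-fold higher number from compound 2 to compound 3 (0.47 log units; beyond the scatter) and yet, against the iodinated tail, a 2.3-fold lower number from compound 1 to compound 3 (0.37 log units; beyond the scatter) so the tail's identity sets the order of all three compounds. Nothing available explains that order.

On these data alone, how unsubstituted phenyl or naphthalen-1-yl would compare remains open. So does whether an amine on the ring or a longer chain would move the number.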